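The source may hold more compounds than are shown below. What is called first, only, known or untested is meant among the compounds shown, and "the series" means these compounds.

In an ADME assay on THP-1 cells (Homo sapiens) for cytotoxicity, read by flow cytometry, with a stated time of 72 h (on this read-out lower numbers stand for stronger inhibition and higher numbers for weaker inhibition), three compounds have been measured. Compound 1 `N/C(=N\O)c1ccc(C(=O)CS(=O)(=O)c2ccc(/C(N)=N/O)cc2)cc1` reaches only a limit of the assay, > 125000 nM (the limit of > 125000 nM in this assay, at which 1 of the 3 values shown sits). Compound 2 `CC1(c2ccccc2)CC(S(=O)(=O)c2ccc(/C(N)=N/O)cc2)=C(c2ccc(/C(N)=N/O)cc2)O1` gives 99500 nM. Compound 3 `CC1(Cc2ccccc2)CC(S(=O)(=O)c2ccc(/C(N)=N/O)cc2)=C(c2ccc(Nc3cccc(/C(N)=N/O)c3)cc2)O1` gives 44000 nM, the lower of the two actual numbers, and its gap to compound 2 lies beyond the usual scatter. Compound 4 `CC1(Cc2ccccc2)CC(S(=O)(=O)c2ccc(/C(N)=N/O)cc2)=C(c2ccc(/C=C/c3ccc(/C(N)=N/O)cc3)cc2)O1` has not yet been measured; it differs from compound 3 in one place: a group of 12 heavy atoms (9 carbon, 2 nitrogen, 1 oxygen; one six-membered aromatic ring of carbon only) in place of a group of 11 heavy atoms (7 carbon, 3 nitrogen, 1 oxygen; one six-membered aromatic ring of carbon only), on an aromatic carbon. Among the measured compounds shown here, no measured pair shows the effect of such a swap, so no step beyond the scatter is expected in this assay, and a small move in either direction is equally possible. For compound 4 the expected value is 35000 nM, with a range from 12000 nM to 110000 nM. That estimate means an expected step of a 1.3-fold lower number from compound 3 to compound 4 (0.10 log units; within the scatter).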

Compound 4, half-maximal inhibitory concentration: 23400 nM
For compound 4 the middle estimate is 1.5-fold (0.17 log units) above the measured one; the range from low to high includes it.
By their numbers in this assay, from the lowest: compounds 4 and 3 (each within the scatter of the next); then compound 2. At a limit, above all of these: compound 1.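

At this aromatic carbon, para to a large group, the swap gives a 1.9-fold lower number from compound 3 to compound 4 (0.27 log units; within the scatter) in this assay, the first step measured at this position. Going from the group with 3 hydrogen-bond donors and 1 double bond outside aromatic rings to the one with 2 of each does not move the read-out beyond the scatter. Nothing measured here offers a reason for the size of this step.

Still open, as far as these compounds go, is whether a carboxylic acid or a plain amine on the outer aromatic ring would shift the number beyond the scatter. This single pair also cannot say whether the same swap behaves alike on another core.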